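A few compounds are considered here, and "the series" means these few. Any claim that something is new, unique, unknown or untested is made for them only; others in the source may bear on it.

Compound 1 `CC(=O)Nc1ccc(-c2nn(Cc3ccc(C#N)cc3)c(=O)c3ccccc23)c(F)n1`: > 100000 nM
Compound 2 `Cc1cc(-c2ccc(F)nc2F)cn(Cc2ccc(Cl)cc2)c1=O`: 90800 nM
Compound 3 `N#Cc1ccc(Cn2nc(-c3ccc(F)nc3F)c3ccccc3c2=O)cc1`: not yet measured

In an ADME assay on HepG2 2.2.15 cells (Homo sapiens) for cytotoxicity, read by MTT assay, with a stated time of 8 days (a higher number here means that more compound is tolerated, a lower number that less compound is tolerated), compound 1 gives > 100000 nM, which is a limit of the assay and not a number. Compound 3 carries fluoro in place of acetamido on an aromatic carbon of the ring with 1 nitrogen: fluoro in place of acetamido on an aromatic carbon. Within the data shown here, no measured pair shows the size of this swap. Compound 2, a different structure, gives 90800 nM in this assay, so compound 3 is expected to stay well tolerated, with little or no change beyond the scatter and any shift towards less compound tolerated. The expected change is an at least 1.2-fold lower number from compound 1 to compound 3 (0.09 log units; that floor lies within the scatter). For compound 3 the estimated value is 80000 nM, within an expected range of 30000 nM to 150000 nM.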

Compound 3, half-maximal cytotoxic concentration: > 100000 nM
Compound 3: no number, only a limit; the forecaster's own chance of this, stated with the estimate: 45%; middle value at least 1.2-fold (0.09 log units) away from the limit.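

No step can be read from compound 1 to compound 3, because both sit at the same limit: the limit of > 100000 nM in this assay, at which 2 of the 3 values shown sit.

The compounds shown leave open how much compound is tolerated past that limit with acetamido or with fluoro in this place.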